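The source may hold more compounds than are shown below. What is called first, only, known or untested is meant among the compounds shown, and "the series" means these compounds.

Within the data shown here, compound 1, with the structure `COc1cc2c(/C=C3/C(=O)Nc4ccc(O)cc43)c(Cl)n(Cc3cc(OC)c(OC)c(OC)c3)c2cc1C`, is one of two compounds measured in a functional assay on cells (Cancer cell lines, Homo sapiens) for cytotoxicity, with a stated time of 48 h (a lower number here means a stronger inhibitor of growth, a higher number a weaker inhibitor of growth), where compound 1 gives 2290 nM. The other measured compound, compound 2 with the structure `COc1ccc2c(c1)/C(=C\c1c(Cl)n(C/C=C/c3ccccc3)c3ccccc13)C(=O)N2`, gives 2090 nM in this assay. These two values lie within the usual scatter of each other, so neither compound can be called the stronger inhibitor of growth on this evidence. Compound 3, with the structure `COc1ccc2c(c1)/C(=C\c1c(Cl)n(Cc3cc(OC)c(OC)c(OC)c3)c3cc(C)c(OC)cc13)C(=O)N2`, has not yet been measured in this assay. It differs from compound 1 in one place: methyl in place of hydrogen on an oxygen on an aromatic ring, which turns a hydroxy group into a methoxy group. Among the measured compounds shown here, no pair of measured compounds differs in only this way, so the size of the step cannot be read from the numbers already in hand. Compound 2 does carry a methoxy group at this position and shows a value close to that of compound 1, but it differs from compound 1 elsewhere as well. The step from compound 1 to compound 3 is therefore expected to be small, a 1.1-fold lower number from compound 1 to compound 3 (0.06 log units; within the scatter), with no clear direction beyond the scatter. Compound 3 is expected to give about 2000 nM in this assay, within a range of 700 nM to 6000 nM.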

Compound 3, concentration for 50% growth inhibition: 14500 nM
Estimate against measurement, compound 3: 7.3-fold (0.86 log units) below, and the stated range ends below it.
By their numbers in this assay, from the lowest: compounds 2 and 1 (each within the scatter of the next); then compound 3.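

In this assay, among these compounds, turning the hydroxy group of compound 1 into a methoxy group gives a 6.3-fold higher number from compound 1 to compound 3 (0.80 log units; beyond the scatter), and this is the first change at a single place that can be read directly from the measurements. It shows that this oxygen on an aromatic ring is not indifferent to what it carries: a single added methyl, with one heavy atom and no net charge, leaves compound 3 a clearly weaker inhibitor of growth than compound 1. No measurement available here explains why the number rises, so the step stands as an observation and not as a mechanism.

A single pair cannot show whether the loss follows from removing the hydrogen on this oxygen or from adding the methyl, and an amine in the place of the hydroxy group, or an ethoxy group in the place of the methoxy group, would help to separate the two. From the compounds shown here alone, it also remains open whether the same change would produce a step of similar size on a core carrying a different group on its ring nitrogen, such as a longer chain.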